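Replacing the aryl group of an inactive compound

The source may hold more compounds than are shown below. What is called first, only, known or untested is meant among the compounds shown, and "the series" means these compounds.

Measured in a functional assay on A549 cells (Homo sapiens) for antiproliferative activity, read by MTT assay, with a stated time of 72 h; a lower number here means a stronger inhibitor, a higher number a weaker inhibitor:
compound 1 `O=C(N/N=C/c1cccc([N+](=O)[O-])c1)Nc1ccc(Oc2ccnc3[nH]ccc23)c(F)c1`: 3640 nM
compound 2 `O=C(N/N=C/c1cccc(Cl)c1Cl)Nc1ccc(Oc2ccnc3[nH]ccc23)c(F)c1`: "not active" (no number reported)
compound 3 `CC(C)(C)c1cc(/C=N/NC(=O)Nc2ccc(Oc3ccnc4[nH]ccc34)c(F)c2)cc(C(C)(C)C)c1O`: 13600 nM

Compound 2 has no number that would place it on the scale. It is reported only as "not active" (no number reported), so any step away from it can be judged by direction but not measured exactly. Compound 4 `O=C(N/N=C/c1cc(Br)c(O)c(Br)c1)Nc1ccc(Oc2ccnc3[nH]ccc23)c(F)c1` has not yet been measured. It keeps the shared core but differs at one place: 3,5-dibromo-4-hydroxyphenyl in place of 2,3-dichlorophenyl on a carbon with a double bond to nitrogen. In words, it has 3,5-dibromo-4-hydroxyphenyl in place of 2,3-dichlorophenyl on a carbon with a double bond to nitrogen. The nearest measured comparison is compound 3, which also has a hydroxy group on its phenyl ring and gives 13600 nM in this assay. On that basis, the expected step from compound 2 is towards a stronger result, from no reported number to a measurable but still weak value. For compound 4 the estimated value is 9000 nM, with an expected range from 2500 nM to 35000 nM.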

Compound 4, half-maximal inhibitory concentration: 16200 nM
Beside the measured number, compound 4's estimate is 1.8-fold (0.26 log units) below it; the range from low to high includes it.
By their numbers in this assay, from the lowest: compound 1; then compounds 3 and 4 (each within the scatter of the next).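

In this assay, 3,5-dibromo-4-hydroxyphenyl in place of 2,3-dichlorophenyl turns compound 2, reported only as "not active", into compound 4, which has a measurable value, so a change at this position can bring a compound onto the scale, although the size of that step cannot be read. The group still does not match 3-nitrophenyl, with a 4.5-fold higher number from compound 1 to compound 4 (0.65 log units; beyond the scatter). Compound 3, whose phenyl ring also carries a hydroxy group, gives 13600 nM and compound 4 gives 16200 nM, values within the usual scatter of each other.

Nothing measured here gives a reason for these differences. On these data alone, it remains open whether the hydroxy group or the bromines account for the change from compound 2, and whether an amine or a carboxylic acid on this phenyl ring would give a lower number.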